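Swapping amino for hydroxy on a compound at the assay limit

The source may report more compounds than this note shows. Statements on the series, on what has been measured and on what is new or still open speak of the compounds shown alone.

In an ADME assay on L1210/0 cells (Mus musculus) for cytotoxicity, with a stated time of 48 h (a lower number here means a stronger inhibitor, a higher number a weaker inhibitor), the measured compounds read as follows.

- compound 1 `CO[C@@H]1OC[C@@H](OC(C)=O)[C@@H](OC(C)=O)[C@]1(F)n1ccc(=O)[nH]c1=O` with 55000 nM
- compound 2 `CC(=O)OCCOCn1cnc2c(Cl)ncnc21` with 163000 nM
- compound 3 `Nc1nc(N)c2nnn([C@H]3CCCC[C@H]3CO)c2n1` with > 200000 nM (a limit)

Compound 1 and compound 2 each return a number in this assay and so give a measured reading. Compound 3 does not: its entry of > 200000 nM is a limit and not a number.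

Compound 4 `Nc1nc(O)c2nnn([C@H]3CCCC[C@H]3CO)c2n1` has not yet been measured. It differs from compound 3 by hydroxy in place of amino on an aromatic carbon and in no other place.

Among the compounds with values here, no two measured compounds differ in one place, so no measured step gives the size of such a change. The expectation therefore rests on compound 3 alone, with its limit of > 200000 nM as the only anchor. The step expected a number no higher from compound 3 to compound 4 (the limit leaves the size open) is none beyond the usual scatter. A reported limit is expected to be somewhat more likely than a number for compound 4 in this assay when it is tested. The estimated value for compound 4 is 200000 nM with an expected range from 80000 nM to 400000 nM in this account.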

Compound 4, half-maximal inhibitory concentration: > 200000 nM
Compound 4 was reported as a limit; the forecaster's own chance of this, stated with the estimate: 65%; the middle value sits exactly at the limit.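

No step from compound 3 to compound 4 can be read in this assay, because both compounds are reported as limits and not as numbers: the limit of > 200000 nM in this assay, at which 2 of the 4 values shown sit.

The compounds shown leave open whether hydroxy in place of amino on an aromatic carbon shifts the reading in this assay at all, and by how much.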